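Restoring an aryl group on the ring nitrogen

The source may hold more compounds than are shown below. What is called first, only, known or untested is meant among the compounds shown, and "the series" means these compounds.

Compound 2 `CCN1C(=O)CSC1c1cccc(C(=O)NCCCCc2ccccc2)c1` gives 0% in a functional assay on MG-63 cells (Homo sapiens) for inhibition, read by CCK-8 assay, with a stated time of 72 h, tested at 1 uM (a lower number here means less inhibition, a higher number more inhibition at the concentration tested (going by the name of the read-out)), the lowest of the two numbers at hand. Compound 1 `O=C(NCCCCc1ccccc1)c1cccc(C2SCC(=O)N2c2ccccc2)c1` gives 89% in this assay, and the step of a number 89 percentage points lower from compound 1 to compound 2 (beyond the scatter) shows how much was lost when the aryl group was exchanged for a small chain. Compound 3 `O=C(NCCCCc1ccccc1)c1cccc(C2SCC(=O)N2c2cccc(F)c2)c1` carries the change (3-fluorophenyl in place of ethyl on an amide-type nitrogen in a ring), which largely reverses that step while adding a fluorine. A large rise is therefore expected, and compound 3 is estimated at 80% (range 55% to 95%), a step of a number 80 percentage points higher from compound 2 to compound 3 (beyond the scatter).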

Compound 3, a percentage reported as inhibition, at one concentration (the size of the read-out at that concentration, not a potency): 92%
Compound 3: middle estimate off by 12 percentage points, on the low side; the measured number falls inside the stated range.
By their numbers in this assay, from the lowest: compound 2; then compounds 1 and 3 (each within the scatter of the next).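

With the 3-fluorophenyl group on the ring nitrogen, this assay shows a number 92 percentage points higher from compound 2 to compound 3 (beyond the scatter) and so the high number at this position is not unique to plain phenyl. Fluoro in place of hydrogen on the aromatic ring gives a number 3 percentage points higher from compound 1 to compound 3 (within the scatter) and so compound 1 and compound 3 cannot be told apart here. Nothing at hand explains why the aryl compounds differ so much from the ethyl compound. Still open, going by these compounds, is whether a ring is needed on this nitrogen at all, since a longer chain such as butyl could also serve. Also open, on these data alone, is how a phenyl ring bearing an amine or a carboxylic acid would behave.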